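This account rests on a few compounds, and the source may have more. Where it says the series, first, only, none or still open, it means among the compounds named here.

In a functional assay on MDA-MB-231 cells (Homo sapiens) for inhibition, read by MTT assay, with a stated time of 48 h (a higher number here means a weaker inhibitor of growth, a lower number a stronger inhibitor of growth), compound 1 `FC(F)(F)c1cc(NC(=S)Nc2ccc3ncnc(Nc4cccc(Br)c4)c3c2)ccc1Cl` gives 1100 nM. Compound 2 `CNC(=S)Nc1ccc2ncnc(Nc3cccc(Br)c3)c2c1` stands only at a limit of the assay, > 30000 nM. Compound 3 `S=C(Nc1cccnc1)Nc1ccc2ncnc(Nc3cccc(Br)c3)c2c1` carries pyridin-3-yl in place of methyl on an amide-type nitrogen. For the measured compounds named here, one measured step bears on this change: an at least 27-fold higher number from compound 1 to compound 2 (1.43 log units; beyond the scatter), a large one, which put methyl where 4-chloro-3-(trifluoromethyl)phenyl had been. Pyridin-3-yl is a different group from that one, so only part of that size is expected on going back to a ring, and the number should fall. The expected change is an at least 5.0-fold lower number from compound 2 to compound 3 (0.69 log units; beyond the scatter). For compound 3 the estimated value is 6000 nM, with an expected range of 1500 nM to 30000 nM.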

Compound 3, concentration for 50% growth inhibition: > 30000 nM
Compound 3: a limit, no number; the forecaster's own chance of this, stated with the estimate: 25%; middle value at least 5.0-fold (0.69 log units) from the limit.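

On this amide-type nitrogen, a ring alone does not bring back the growth inhibition of compound 1 in this assay: pyridin-3-yl in place of 4-chloro-3-(trifluoromethyl)phenyl gives an at least 27-fold higher number from compound 1 to compound 3 (1.43 log units; beyond the scatter). The result for compound 3 is a limit of the assay and not a number. The step from compound 2 to compound 3 cannot be read, since both compounds stand at that limit: the limit of > 30000 nM in this assay, at which 2 of the 3 values shown sit.

Still open, on these data alone, is which part of 4-chloro-3-(trifluoromethyl)phenyl matters here. A plain phenyl ring, or a phenyl ring carrying only chloro or only trifluoromethyl, would help to separate these contributions.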